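The compounds below may be only part of what the source reports. "The series", "measured", "known", "first", "only" and "open" are said of these compounds alone.

Compounds measured so far:
Compound 1, `O=C(O)CC(O)(CSCc1ccc(Cl)cc1Cl)C(=O)O`: 410000 nM
Compound 2, `O=C(O)CC(O)(CSCCCCCCc1ccccc1Cl)C(=O)O`: 69000 nM

In an assay on isolated protein for inhibition of ATP-citrate synthase (Rattus norvegicus) (a higher number here means a weaker inhibitor, a lower number a stronger inhibitor), compound 2 gives 69000 nM, the lowest of the two numbers. Compound 1 gives 410000 nM, a higher number, and the gap between these two lies beyond the usual scatter of this assay. Compound 3, `O=C(O)CC(O)(CSCCCCCCc1cccc(Cl)c1)C(=O)O`, has not yet been measured in this assay. It differs from compound 2 in one place: 3-chlorophenyl in place of 2-chlorophenyl on a saturated chain carbon, six bonds along the chain from a sulfur. Among the compounds with values here, no measured pair shows an exchange of this kind, so nothing among the present data tells how swapping one chlorophenyl for the other acts on the inhibition constant. The shared core and the saturated chain stay intact, and the two compounds contain the same atoms joined differently. The step from compound 2 to compound 3 is therefore expected to be small, within the usual scatter and without a clear direction: a 1.2-fold lower number from compound 2 to compound 3 (0.06 log units; within the scatter). For compound 3 in this assay the estimate is 60000 nM, with a range from 25000 nM to 160000 nM.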

Compound 3, inhibition constant: 150000 nM
Compound 3: the middle estimate sits 2.5-fold (0.40 log units) below what was measured, and the stated range covers the measured number.
By their numbers in this assay, from the lowest: compound 2; then compound 3; then compound 1.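

In this assay, the exchange of 2-chlorophenyl for 3-chlorophenyl on a saturated chain carbon, six bonds along the chain from a sulfur, comes out as a 2.2-fold higher number from compound 2 to compound 3 (0.34 log units; beyond the scatter), a modest step that favours compound 2. Within the data shown here, this is the first pair in the set that differs in one place, and since the two groups hold the same atoms joined differently, it shows that the inhibition constant responds to the arrangement of the chlorophenyl group alone, with no change in composition. Nothing available explains why the number moves in this direction.

Whether this step belongs to a wider trend remains open, as the compounds shown give no reading for 4-chlorophenyl, for an unsubstituted phenyl, or for a bromine or a methoxy group in place of the chlorine on this ring. Also open, going by these compounds, is how the step would look on a shorter or longer chain, and compound 1 cannot settle that, as it differs from compound 2 and compound 3 in more than one place.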